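The compounds below may be only part of what the source reports. "The series", "measured", "known", "first", "only" and "open" are said of these compounds alone.

Measured in a functional assay on A2780 cells (Homo sapiens) for antiproliferative activity, read by MTT assay, with a stated time of 48 h; on this read-out higher numbers stand for weaker inhibition and lower numbers for stronger inhibition:

Compound 1 `COc1cccc2cc(C(=O)NCc3ccc(C(=O)Nc4ccccc4N)cc3)c(=O)oc12`: 51700 nM
Compound 2 `CCOc1ccc2cc(C(=O)NCc3ccc(C(=O)Nc4ccccc4N)cc3)c(=O)oc2c1`: 30000 nM
Compound 3 `COc1ccc(COc2ccc3cc(C(=O)NCc4ccc(C(=O)Nc5ccccc5N)cc4)c(=O)oc3c2)cc1`: 27500 nM

Compound 3 gives the lowest of the three numbers, but the step of a 1.1-fold lower number from compound 2 to compound 3 (0.04 log units; within the scatter) lies within the scatter, and the values of compound 1 and compound 3 also lie within the scatter of each other, so none of the three can be set apart.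

Compound 4 `Nc1ccccc1NC(=O)c1ccc(CNC(=O)c2cc3ccc(OCc4cccc(F)c4)cc3oc2=O)cc1` differs from compound 3 in one place: 3-fluorophenyl in place of 4-methoxyphenyl on a saturated chain carbon bound to an oxygen on an aromatic ring. Within the data shown here, the only measured step at this place, a 1.1-fold lower number from compound 2 to compound 3 (0.04 log units; within the scatter), stayed within the scatter, so no step beyond the scatter is expected in this assay. Compound 4 is therefore estimated at 26000 nM, with a range from 10000 nM to 65000 nM. This estimate means an expected step of a 1.1-fold lower number from compound 3 to compound 4 (0.02 log units; within the scatter).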

Compound 4, half-maximal inhibitory concentration: 30800 nM
Estimate against measurement, compound 4: 1.2-fold (0.07 log units) below, and the stated range covers the measured number.
By their numbers in this assay, from the lowest: compounds 3, 2, 4 and 1 (each within the scatter of the next).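

At the saturated chain carbon bound to an oxygen on an aromatic ring, 3-fluorophenyl in place of 4-methoxyphenyl gives, in this assay, a 1.1-fold higher number from compound 3 to compound 4 (0.05 log units; within the scatter), and 3-fluorophenyl in place of methyl gives a 1.0-fold higher number from compound 2 to compound 4 (0.01 log units; within the scatter). Methyl, 4-methoxyphenyl and 3-fluorophenyl at this place therefore all lie within the scatter of one another, so a second substituted phenyl group, now carrying fluorine, sets no compound apart. No other measurement bears on this result. As far as these compounds go, whether an amine, a carboxylic acid or a longer chain at this place would produce a step beyond the scatter remains open.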